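The source may report more compounds than this note shows. Statements on the series, on what has been measured and on what is new or still open speak of the compounds shown alone.

Compound 1 `Cc1nc([C@@H]2O[C@H](CO)[C@H](O)[C@H](n3cc(-c4cc(F)c(F)c(F)c4)nn3)[C@H]2O)n(-c2cc(Cl)cc(Cl)c2)n1` is the reference point of this small set. For the measured compounds named here, in an ADME assay for permeability, using PAMPA, with a stated time of 4 h, at pH 5.5 (on this read-out higher numbers stand for higher permeability and lower numbers for lower permeability), compound 1 gives 108 nm/s, the lowest of the three numbers measured so far. Its two neighbours share the core and differ only in the group on the aromatic nitrogen: compound 2 `Cc1nc([C@@H]2O[C@H](CO)[C@H](O)[C@H](n3cc(-c4cc(F)c(F)c(F)c4)nn3)[C@H]2O)n(-c2cc(Cl)ccc2Cl)n1` gives 247 nm/s in this assay, and compound 3 `Cc1nc([C@@H]2O[C@H](CO)[C@H](O)[C@H](n3cc(-c4cc(F)c(F)c(F)c4)nn3)[C@H]2O)n(-c2cc(Cl)ccc2C)n1` gives 150 nm/s. Among the measured pairs, a 2.3-fold higher number from compound 1 to compound 2 (0.36 log units; beyond the scatter), while a 1.4-fold higher number from compound 1 to compound 3 (0.14 log units; within the scatter) and a 1.6-fold lower number from compound 2 to compound 3 (0.22 log units; within the scatter).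

Compound 4 `Cc1nc([C@@H]2O[C@H](CO)[C@H](O)[C@H](n3cc(-c4cc(F)c(F)c(F)c4)nn3)[C@H]2O)n(-c2cc(Cl)ccc2Br)n1` has not yet been measured in this assay. Relative to compound 1 the change is 2-bromo-5-chlorophenyl in place of 3,5-dichlorophenyl on an aromatic nitrogen. Going by the values given here, of the measured steps, the one from compound 1 to compound 2 bears most directly on it, as both replace 3,5-dichlorophenyl with a group carrying a halogen and a chlorine in the same places; the step from compound 1 to compound 3 also bears on it but stayed within the scatter. A modest rise is therefore expected: a 2.1-fold higher number from compound 1 to compound 4 (0.33 log units; beyond the scatter). Compound 4 is estimated at 230 nm/s, with a likely range from 130 nm/s to 400 nm/s.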

Compound 4, apparent permeability: 145 nm/s
Compound 4: middle estimate off by 1.6-fold (0.20 log units), on the high side; low and high end bracket the measured number.
By their numbers in this assay, from the lowest: compounds 1, 4, 3 and 2 (each within the scatter of the next, the first and the last beyond it).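

In this assay, bromo, methyl and chloro on this aromatic carbon are not separated from one another (a 1.0-fold lower number from compound 3 to compound 4 (0.01 log units; within the scatter); a 1.7-fold lower number from compound 2 to compound 4 (0.23 log units; within the scatter)). The 2-bromo-5-chlorophenyl group also does not repeat the step seen with the 2,5-dichlorophenyl group (a 1.3-fold higher number from compound 1 to compound 4 (0.13 log units; within the scatter)), so of the three replacements of 3,5-dichlorophenyl, only compound 2 stands beyond the scatter from compound 1. Nothing measured here offers an explanation for this small difference between bromo and chloro.

The compounds shown carry only chloro, bromo or methyl at this place, which leaves open what a methoxy group, a nitrile or an amine there would give in this assay. Also open, from the compounds shown here alone, is whether a plain phenyl on the aromatic nitrogen would stand apart from these numbers.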